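Notes on replacing the amide aryl group in the series

The source may report more compounds than this note shows. Statements on the series, on what has been measured and on what is new or still open speak of the compounds shown alone.

Compound 1 `COc1ccc2nc(C(F)(F)F)cc(OCC(=O)Nc3cc(C)cc(C)c3)c2c1` and compound 2 `CCCc1cc(OCC(=O)Nc2cc(C)cc(C)c2)c2cc(OC)ccc2n1` share a core with compound 3 `COc1ccc2nc(C)cc(OCC(=O)Nc3ccc(Br)c(C)c3)c2c1` and differ from it both on the core and at the amide-type nitrogen. In a physicochemical assay for solubility, in phosphate buffer, measured as kinetic solubility, with a stated time of 1 h, at pH 7.4 (on this read-out higher numbers stand for higher solubility and lower numbers for lower solubility), compound 1 gives 15000 nM. In this assay compound 2 gives 12000 nM. For the measured compounds named here, the only measured step, a 1.3-fold lower number from compound 1 to compound 2 (0.10 log units; within the scatter), concerns an aromatic carbon of the core and not the amide-type nitrogen. Compound 3 sits at the floor of this assay, giving < 1000 nM, which is a limit and not a number; (the limit of < 1000 nM in this assay, at which 1 of the 3 values shown sits). Compound 4 `COc1ccc2nc(C)cc(OCC(=O)Nc3nc(C)c(C)s3)c2c1` differs from compound 3 by 4,5-dimethyl-1,3-thiazol-2-yl in place of 4-bromo-3-methylphenyl on an amide-type nitrogen. Going by the values given here, no measured step covers a change at this place, and compound 3 is known only as a limit, so the step to compound 4 has no measured baseline; the expectation rests on the range in which compound 1 and compound 2 were found and on the limit alone. Compound 4 is expected to give 3000 nM, between 800 nM and 12000 nM. This expectation amounts to the step of an at least 3.0-fold higher number from compound 3 to compound 4 (0.47 log units; beyond the scatter), taken from a limit.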

Compound 4, solubility: 31500 nM
Beside the measured number, compound 4's estimate is 11-fold (1.02 log units) below it; the measured number lies above the stated range.
By their numbers in this assay, from the lowest: compounds 2 and 1 (each within the scatter of the next); then compound 4. At a limit, below all of these: compound 3.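

In this assay, the amide-type nitrogen now has its first measured step, and it is large: 4,5-dimethyl-1,3-thiazol-2-yl in place of 4-bromo-3-methylphenyl gives an at least 31-fold higher number from compound 3 to compound 4 (1.49 log units; beyond the scatter). For the compounds shown here, the only earlier step, a 1.3-fold lower number from compound 1 to compound 2 (0.10 log units; within the scatter), lay on an aromatic carbon of the core, so the earlier compounds showed nothing about this place. Compound 3 is known only as a limit, so the step gives a bound and not a size: the limit of < 1000 nM in this assay, at which 1 of the 4 values shown sits.

Open, going by these compounds, is whether the step carries over to the core of compound 1 or compound 2, and whether it follows the change of ring or the 2 hydrogen-bond acceptors that enter with it. On these data alone, how an amine or a carboxylic acid on the ring at this nitrogen would read also stays open.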